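The compounds below may be only part of what the source reports. "The series", "measured", "known", "first", "only" and "open" are said of these compounds alone.

Measured so far:
- compound 1, `Cc1ccc(CN(C)C(=O)c2nn(-c3ccc(F)cc3)c(OC[C@@H](O)C[C@@H](O)CC(=O)O)c2C(C)C)cc1`, in an assay on microsomes from liver for inhibition of 3-hydroxy-3-methylglutaryl-coenzyme A reductase (Rattus norvegicus); on this read-out lower numbers stand for stronger inhibition and higher numbers for weaker inhibition: 37 nM
- compound 2, `Cc1ccccc1CNC(=O)c1nn(-c2ccc(F)cc2)c(OC[C@@H](O)C[C@@H](O)CC(=O)O)c1C(C)C`, in this assay: 17 nM

Compound 2 has the lowest of the two numbers, and its nearest neighbour is compound 1, with the step of a 2.2-fold lower number from compound 1 to compound 2 (0.34 log units; beyond the scatter) lying beyond the usual scatter. That single step is the whole record from which to judge the next compound.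

Compound 3, `COc1cccc(CNC(=O)c2nn(-c3ccc(F)cc3)c(OC[C@@H](O)C[C@@H](O)CC(=O)O)c2C(C)C)c1`, differs from compound 2 in one place: 3-methoxyphenyl in place of 2-methylphenyl on a saturated chain carbon bound to an amide-type nitrogen. Going by the values given here, the only measured step bears on it loosely at best, since that step exchanged both the substituent on the amide-type nitrogen and the substituent on the ring in one move and came out modest. Compound 3 keeps the amide hydrogen of compound 2 and alters only the ring substituent, so in this assay no step beyond the scatter is expected in either direction, with a slight lean toward a higher number. Compound 3 is therefore expected to give 25 nM, with a range of 10 nM to 60 nM. The step this estimate implies is a 1.5-fold higher number from compound 2 to compound 3 (0.17 log units; within the scatter).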

Compound 3, half-maximal inhibitory concentration: 16 nM
Compound 3: middle estimate off by 1.6-fold (0.19 log units), on the high side, within the range that was stated.
By their numbers in this assay, from the lowest: compounds 3 and 2 (each within the scatter of the next); then compound 1.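

In this assay, exchanging 2-methylphenyl for 3-methoxyphenyl on the saturated chain carbon bound to the amide-type nitrogen gives a 1.1-fold lower number from compound 2 to compound 3 (0.03 log units; within the scatter) and so does not separate the two groups, even though the entering group brings an oxygen and a hydrogen-bond acceptor that the leaving group lacks. The comparison with compound 1 gives a 2.3-fold lower number from compound 1 to compound 3 (0.36 log units; beyond the scatter) and runs the same way as a 2.2-fold lower number from compound 1 to compound 2 (0.34 log units; beyond the scatter), so both compounds that keep the amide hydrogen have lower numbers than compound 1, whose amide nitrogen carries a methyl group. That comparison changes the nitrogen substituent and the ring substituent together, and nothing available here offers an explanation for the result.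

The compounds shown do not separate the contribution of the methyl group on the amide nitrogen from that of the ring substituent, since no pair differs in that methyl group alone. They also leave open whether this position would accept a ring bearing an amine or a carboxylic acid, or a longer chain between the amide nitrogen and the ring.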